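The source may hold more compounds than are shown below. What is called first, only, known or untested is meant among the compounds shown, and "the series" means these compounds.

Measured compounds in a functional assay on HCT-116 cells (Homo sapiens) for cytotoxicity, read by MTT assay, with a stated time of 24 h; a higher number here means a weaker inhibitor, a lower number a stronger inhibitor:
- compound 1 `COc1cccc(-n2cc(COc3c(/C=C\C(=O)O)ccc(OC)c3CC=C(C)C)nn2)c1` gives 21600 nM
- compound 2 `COc1ccc(/C=C\C(=O)O)c(OCc2cn(-c3ccc(CO)cc3)nn2)c1CC=C(C)C` gives 31700 nM
- compound 3 `COc1ccc(/C=C\C(=O)O)c(OCc2cn(-c3ccc(C#N)cc3)nn2)c1CC=C(C)C` gives 21000 nM

The three numbers sit in a narrow band. Compound 3 has compound 1 as its nearest neighbour, a 1.0-fold lower number from compound 1 to compound 3 (0.01 log units; within the scatter), and compound 2 a little further off, a 1.5-fold lower number from compound 2 to compound 3 (0.18 log units; within the scatter); neither gap counts as a real difference, and the remaining pair is likewise flat, a 1.5-fold higher number from compound 1 to compound 2 (0.17 log units; within the scatter). All three exchanges concern only the aryl group on the aromatic nitrogen of the triazole-type ring.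

Compound 4 `COc1ccc(/C=C\C(=O)O)c(OCc2cn(-c3ccccc3C#N)nn2)c1CC=C(C)C` continues in the same place: 2-cyanophenyl in place of 4-cyanophenyl on an aromatic nitrogen. The relevant precedents are the three steps above, each within the scatter, so no step beyond the scatter is expected in this assay in either direction; the nitrile and the aryl ring are kept, only the bearing of the nitrile on the ring moves. Compound 4 is therefore estimated at 22000 nM, range 11000 nM to 44000 nM, which corresponds to an expected step of a 1.0-fold higher number from compound 3 to compound 4 (0.02 log units; within the scatter).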

Compound 4, half-maximal inhibitory concentration: 38300 nM
Compound 4: the middle estimate sits 1.7-fold (0.24 log units) below what was measured; the range from low to high includes it.
By their numbers in this assay, from the lowest: compounds 3, 1, 2 and 4 (each within the scatter of the next).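

In this assay, 2-cyanophenyl in place of 4-cyanophenyl on the aromatic nitrogen gives a 1.8-fold higher number from compound 3 to compound 4 (0.26 log units; within the scatter), so with the same atoms joined differently, the bearing of the nitrile on the aryl ring produces no step beyond the scatter. The other two exchanges at this nitrogen read the same, with a 1.2-fold higher number from compound 2 to compound 4 (0.08 log units; within the scatter) and a 1.8-fold higher number from compound 1 to compound 4 (0.25 log units; within the scatter), which leaves 3-methoxyphenyl, 4-(hydroxymethyl)phenyl, 4-cyanophenyl and 2-cyanophenyl all within the scatter of one another. No measurement available here accounts for this flat picture.

Open, going by these compounds, is whether an aryl ring carrying an amine or a carboxylic acid would leave this narrow band. Also open, on these data alone, is whether a longer alkyl chain on the same nitrogen, with no aryl ring at all, would do so.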